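Efficacy held when a pyridine replaced the fluorophenyl

This account rests on a few compounds, and the source may have more. Where it says the series, first, only, none or still open, it means among the compounds named here.

Compound 1, `C[C@@H](NC(=O)c1ccc(C#Cc2ccc(F)cc2)cn1)C(C)(C)O`: 66.2%
Compound 2, `C[C@@H](NC(=O)c1ccc(C#Cc2ccncc2)cn1)C(C)(C)O`: 66.6%

In a functional assay on HEK293 cells for positive allosteric modulation of metabotropic glutamate receptor 5 (Rattus norvegicus), read by fluorescence and calcium flux (a higher number here means a larger maximal response, a lower number a smaller maximal response), compound 1 gives 66.2%, the lower of the two numbers, while compound 2 gives 66.6%, the two lying within the scatter of each other. Compound 3, `C[C@@H](NC(=O)c1ccc(C#Cc2ncccc2F)cn1)C(C)(C)O`, has not been measured. It differs from compound 1 in one place: 3-fluoropyridin-2-yl in place of 4-fluorophenyl on a triple-bonded carbon. Among the compounds with values here, the only comparable step, a number 0.4 percentage points higher from compound 1 to compound 2 (within the scatter), also swapped the ring on the triple-bonded carbon and stayed within the scatter, so no step beyond the scatter is expected in this assay. The estimated step is a number 1.2 percentage points lower from compound 1 to compound 3 (within the scatter); compound 3 is expected to give 65%, from 50% to 80%.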

Compound 3, largest response reached (reported as efficacy), in percent of the reference or control that the assay uses: 60.6%
Beside the measured number, compound 3's estimate is 4.4 percentage points above it; the range from low to high includes it.
By their numbers in this assay, from the lowest: compounds 3, 1 and 2 (each within the scatter of the next).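

A third ring on the triple-bonded carbon, 3-fluoropyridin-2-yl, also gives no step beyond the scatter in this assay: the result is a number 5.6 percentage points lower from compound 1 to compound 3 (within the scatter), and likewise a number 6 percentage points lower from compound 2 to compound 3 (within the scatter). This position therefore accepts a ring carrying both fluorine and a ring nitrogen with the maximal response still inside the scatter. Nothing measured here explains why the three readings sit so close.

On these data alone, all three groups are six-membered aromatic rings, so how an amine, a carboxylic acid or a longer chain would behave on this carbon remains open. Without plain pyridin-2-yl, the contributions of the fluorine and the nitrogen in compound 3 cannot be separated.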